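The compounds below may be only part of what the source reports. "The series", "measured", "known", "first", "only" and "open" are said of these compounds alone.

Measured compounds:

compound 1, `CC(=O)[C@@]1(C)C(=O)O[C@@H](OC(=O)c2ccccc2)[C@H]1C`: 3000 nM
compound 2, `CC(=O)[C@]1(C)C(=O)O[C@@H](OC(=O)C(C)(C)C)[C@H]1C`: 7000 nM

Of the compounds shown here, two have been tested in a functional assay on MCF7 cells (Homo sapiens) for cytotoxicity, read by MTT assay; on this read-out lower numbers stand for stronger inhibition and higher numbers for weaker inhibition. Compound 1 gives 3000 nM in this assay, and compound 2 gives 7000 nM. Of these two numbers, compound 2 carries the higher one, and its gap to compound 1 lies beyond the usual scatter of repeated measurements, so compound 2 is the weaker of the pair on this read-out.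

The next compound, compound 3, `CC(=O)[C@]1(C)C(=O)O[C@@H](OC(=O)c2ccccc2)[C@H]1C`, has not yet been measured. It is reached from compound 2 by one change: phenyl in place of tert-butyl on a carbonyl carbon. For the measured compounds named here, no step between two measured compounds follows exactly this change, so its size cannot be read off directly; the only guide is that compound 1, which also carries a benzoate at this position, gives 3000 nM in this assay.

On that basis compound 3 is expected to give a somewhat lower number than compound 2, a step of about a 2.0-fold lower number from compound 2 to compound 3 (0.30 log units; within the scatter), and the estimate for compound 3 is 3500 nM with a likely range from 1500 nM to 9000 nM.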

Compound 3, half-maximal inhibitory concentration: 8000 nM
Compound 3: middle estimate off by 2.3-fold (0.36 log units), on the low side, and the stated range covers the measured number.
By their numbers in this assay, from the lowest: compound 1; then compounds 2 and 3 (each within the scatter of the next).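

In this assay, phenyl in place of tert-butyl on a carbonyl carbon gives no readable difference, with a 1.1-fold higher number from compound 2 to compound 3 (0.06 log units; within the scatter). A readable gap appears instead in the other new comparison, a 2.7-fold higher number from compound 1 to compound 3 (0.43 log units; beyond the scatter), which is modest and goes with a stereocentre at a saturated ring carbon whose drawn configuration is S in one compound and R in the other. That gap can be tied to one structural difference alone: the fact that compounds 1 and 3 differ only in the configuration as drawn

As far as these compounds go, whether other groups on this carbonyl carbon, such as a longer chain or a chain carrying an amine, would also give no readable difference remains open, as does whether tert-butyl would show a similar gap with the stereocentre drawn S. Each conclusion rests on a single pair of compounds, so neither can be taken as a general pattern.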